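Swapping methoxy for chloro on an aromatic ring

This account rests on a few compounds, and the source may have more. Where it says the series, first, only, none or still open, it means among the compounds named here.

Measured in a functional assay on Bel-7402 cells (Homo sapiens) for cytotoxicity, read by MTT assay, with a stated time of 72 h (on this read-out lower numbers stand for stronger inhibition and higher numbers for weaker inhibition), so far
compound 1 `C=C1C(=O)[C@@]23C(=O)OC[C@]4([C@@H](OC(C)=O)CCC(C)(C)[C@H]4C=O)[C@@H]2CC[C@@H]1[C@H]3O` reads 75400 nM
compound 2 `C=C1C(=O)[C@@]23C(=O)OC[C@]4(C(=O)CCC(C)(C)[C@H]4C=O)[C@@H]2CC[C@@H]1[C@H]3OC(=O)c1ccc(OC)cc1` reads 2800 nM
compound 3 `C=C1C(=O)[C@@]23C(=O)OC[C@]4(C(=O)CCC(C)(C)[C@H]4C=O)[C@@H]2CC[C@@H]1[C@H]3OC(=O)c1ccc(F)cc1` reads 3750 nM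

Compound 2 and compound 3 share the low end of these three numbers, within the scatter of each other, while compound 1 stands far higher at 75400 nM on the same read-out. Compound 4 `C=C1C(=O)[C@@]23C(=O)OC[C@]4(C(=O)CCC(C)(C)[C@H]4C=O)[C@@H]2CC[C@@H]1[C@H]3OC(=O)c1ccc(Cl)cc1` has not yet been measured. The change chloro in place of methoxy on an aromatic carbon puts chloro in place of methoxy on an aromatic carbon, para to a large group. Among the measured compounds shown here, the only measured step that bears on it is a 1.3-fold higher number from compound 2 to compound 3 (0.13 log units; within the scatter) where fluoro replaces methoxy on an aromatic carbon, and that step lies within the scatter. For the measured compounds named here, no measured compound carries chloro, so this single step is thin support. The expected 1.1-fold higher number from compound 2 to compound 4 (0.06 log units; within the scatter) is estimated to stay within the scatter, with no direction foreseen. Compound 4 is therefore expected at an estimated 3200 nM with a range from 1500 nM to 7000 nM in this assay once it is tested.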

Compound 4, half-maximal inhibitory concentration: 3840 nM
The estimate for compound 4 lay 1.2-fold (0.08 log units) below the measured number; measured number inside the range.
By their numbers in this assay, from the lowest: compounds 2, 3 and 4 (each within the scatter of the next); then compound 1.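

Chloro on the aromatic carbon para to a large group gives, in this assay, a 1.4-fold higher number from compound 2 to compound 4 (0.14 log units; within the scatter) and a 1.0-fold higher number from compound 3 to compound 4 (0.01 log units; within the scatter). Until now only the fluoro and methoxy pair spoke for this position; with chloro as a second halogen, methoxy, fluoro and chloro all sit together on this read-out, and none of the three can be told apart from the others. Nothing available accounts for this flat result.

The compounds shown leave open whether a group of another kind on this aromatic carbon, such as an amine, a carboxylic acid or a hydroxyl, would carry the number beyond the scatter. They also leave open whether chloro or methoxy would read the same on another carbon of this ring.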